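Triazole nitrogen substituents in a biphenyl diol ether series

This account rests on a few compounds, and the source may have more. Where it says the series, first, only, none or still open, it means among the compounds named here.

Measured compounds:
- compound 1, `O[C@H](COCCOC[C@@H](O)Cc1cn(-c2cccnc2)nn1)Cc1ccc(-c2ccccc2)cc1`: in a functional assay on SGC-7901 cells (Homo sapiens) for inhibition, read by MTT assay, with a stated time of 72 h (on this read-out higher numbers stand for weaker inhibition of growth and lower numbers for stronger inhibition of growth), compound 1 gives 29800 nM
- compound 2, `O[C@H](COCCOC[C@@H](O)Cc1cn(Cc2ccc(C(F)(F)F)cc2)nn1)Cc1ccc(-c2ccccc2)cc1`: compound 2 gives 8700 nM
- compound 3, `O[C@H](COCCOC[C@@H](O)Cc1cn(-c2ccc3c(c2)OCCO3)nn1)Cc1ccc(-c2ccccc2)cc1`: compound 3 gives 6400 nM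

Compound 3 has the lowest number of the three, but its separation from compound 2 is a 1.4-fold lower number from compound 2 to compound 3 (0.13 log units; within the scatter), so the two cannot be ordered. Only against compound 1 does compound 3 stand apart: a 4.7-fold lower number from compound 1 to compound 3 (0.67 log units; beyond the scatter).

Compound 4, `N#Cc1ccc(Cn2cc(C[C@H](O)COCCOC[C@@H](O)Cc3ccc(-c4ccccc4)cc3)nn2)cc1`, is to be measured. The change from compound 3 is 4-cyanobenzyl in place of 2,3-dihydro-1,4-benzodioxin-6-yl on an aromatic nitrogen.

For the measured compounds named here, two measured steps bear on this. The step of a 3.4-fold lower number from compound 1 to compound 2 (0.53 log units; beyond the scatter) shows that a benzyl bearing a trifluoromethyl group on the triazole nitrogen gives a clearly lower number than pyridin-3-yl. The step of a 1.4-fold lower number from compound 2 to compound 3 (0.13 log units; within the scatter) shows that replacing that benzyl with 2,3-dihydro-1,4-benzodioxin-6-yl changes nothing beyond the scatter. Compound 4 carries a benzyl again, differing from compound 2 only by nitrile in place of trifluoromethyl on the benzyl ring. Going by the values given here, no measured step tests that exchange. The nearest reference is therefore compound 2, and compound 4 is expected to fall close to it, with the step from compound 3 estimated as a 1.4-fold higher number from compound 3 to compound 4 (0.15 log units; within the scatter), within the scatter. The estimate for compound 4 in this assay is 9000 nM, with a range from 3000 nM to 30000 nM.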

Compound 4, concentration for 50% growth inhibition: 7700 nM
Compound 4: the middle estimate sits 1.2-fold (0.07 log units) above what was measured; measured number inside the range.
By their numbers in this assay, from the lowest: compounds 3, 4 and 2 (each within the scatter of the next); then compound 1.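

In this assay, the exchange of trifluoromethyl for cyano on the benzyl ring is now tested directly and leaves no separation that can be read (a 1.1-fold lower number from compound 2 to compound 4 (0.05 log units; within the scatter)), so the two benzyl groups cannot be told apart on this read-out. Placing 4-cyanobenzyl on the aromatic nitrogen in place of 2,3-dihydro-1,4-benzodioxin-6-yl also stays within the scatter (a 1.2-fold higher number from compound 3 to compound 4 (0.08 log units; within the scatter)), while placing it there in place of pyridin-3-yl does not (a 3.9-fold lower number from compound 1 to compound 4 (0.59 log units; beyond the scatter)), so among the four compounds only the pyridin-3-yl compound stands apart at this position, and that gap is modest. No measurement available here gives a reason for these results at the aromatic nitrogen.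

The compounds shown leave open whether an unsubstituted benzyl, or a benzyl ring carrying an amine or a carboxylic acid, would stay with compound 2, compound 3 and compound 4 or move away from them. They also leave open whether a longer chain between the aromatic ring and the aromatic nitrogen would change the number on this read-out.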